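From compound 3 to compound 4: adding trifluoromethyl

The source may hold more compounds than are shown below. What is called first, only, known or untested is meant among the compounds shown, and "the series" means these compounds.

In a functional assay on PC-3 cells (Homo sapiens) for inhibition, read by sulforhodamine B assay (on this read-out lower numbers stand for stronger inhibition of growth and higher numbers for weaker inhibition of growth), compound 3 `Cc1ccc2[nH]c(-c3ccc(-c4ccc(-c5ccccc5)cc4)cc3)nc2c1` stands at 100000 nM as the highest of the three measured numbers, which makes it the weakest growth inhibitor among them. Compound 1 `Cc1ccc2[nH]c(-c3ccc(-c4ccc(-c5ccc(N(C)C)cc5)cc4)cc3)nc2c1` reads 8120 nM on the same scale, and compound 2 `Oc1cccc2[nH]c(-c3ccc(-c4ccc(-c5ccc(C(F)(F)F)cc5)cc4)cc3)nc12` reads 2260 nM there. Compound 4 `Cc1ccc2[nH]c(-c3ccc(-c4ccc(-c5ccc(C(F)(F)F)cc5)cc4)cc3)nc2c1`, still unmeasured, has trifluoromethyl in place of hydrogen on an aromatic carbon of compound 3, para to a large group (trifluoromethyl in place of hydrogen on an aromatic carbon). Within the data shown here, one measured step concerns that same carbon: the change a 12-fold higher number from compound 1 to compound 3 (1.09 log units; beyond the scatter) is large and beyond the scatter, with hydrogen in place of dimethylamino. Read backwards, this single pair shows a group there giving a lower number than hydrogen. Compound 2 also carries trifluoromethyl and gives 2260 nM but differs from compound 4 elsewhere in the core, which leaves it only a loose guide. A large step towards stronger inhibition is expected, estimated as a 17-fold lower number from compound 3 to compound 4 (1.22 log units; beyond the scatter) with wide uncertainty. Compound 4 is expected at 6000 nM within an estimated range from 1500 nM to 25000 nM in this assay when measured.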

Compound 4, concentration for 50% growth inhibition: 2010 nM
For compound 4 the middle estimate is 3.0-fold (0.47 log units) above the measured one; low and high end bracket the measured number.
By their numbers in this assay, from the lowest: compounds 4 and 2 (each within the scatter of the next); then compound 1; then compound 3.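

In this assay, trifluoromethyl is a second group on this aromatic carbon that gives a lower number than hydrogen (a 50-fold lower number from compound 3 to compound 4 (1.70 log units; beyond the scatter)), so the earlier drop is not confined to dimethylamino. The two groups do not read alike at this carbon, as trifluoromethyl gives the lower number of the pair (a 4.0-fold lower number from compound 1 to compound 4 (0.61 log units; beyond the scatter)). With trifluoromethyl in place, 5-methyl-1H-benzimidazol-2-yl and 4-hydroxy-1H-benzimidazol-2-yl cannot be told apart, since the step between them lies within the scatter (a 1.1-fold lower number from compound 2 to compound 4 (0.05 log units; within the scatter)).

No evidence is available that would explain these steps. On these data alone, it remains open whether a carboxylic acid or a methoxy group on this carbon would also give a lower number than hydrogen, and whether the two core variants would still match with dimethylamino in place of trifluoromethyl.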